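The source may hold more compounds than are shown below. What is called first, only, known or untested is meant among the compounds shown, and "the series" means these compounds.

Measured so far:
compound 1, `COc1cc(/C=C2\Cc3ccccc3/C(=C\c3ccc([N+](=O)[O-])cc3)C2=O)ccc1O`, 5800 nM
compound 2, `COc1ccc(/C=C2\Cc3ccccc3/C(=C\c3ccc([N+](=O)[O-])cc3)C2=O)cc1OC`, 4400 nM
compound 3, `O=C1/C(=C/c2ccc(O)cc2)CCC/C1=C\c1ccc([N+](=O)[O-])cc1`, > 400000 nM

All three compounds were tested in a functional assay on HSG cells (Homo sapiens) for cytotoxicity; a lower number here means that less compound is tolerated, a higher number that more compound is tolerated. Compound 1 and compound 2 share one core and differ only in methyl in place of hydrogen on an oxygen on an aromatic ring; that change gave a 1.3-fold lower number from compound 1 to compound 2 (0.12 log units; within the scatter). Compound 3 is built on a different core, and the difference between the two cores is not broken down here. For compound 3 this assay reports only a limit, not a number, at the limit of > 400000 nM in this assay, at which 1 of the 3 values shown sits.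

Compound 4, `COc1ccc(/C=C2\CCC/C(=C\c3ccc([N+](=O)[O-])cc3)C2=O)cc1`, has not yet been measured in this assay. It is made from compound 3 by methyl in place of hydrogen on an oxygen on an aromatic ring. The place of this change, on an oxygen on an aromatic ring whose other neighbours are aromatic carbon, is word for word the same as the place of the change from compound 1 to compound 2, so the two are the same change, made on two different cores. Cut one bond further out, the first reads 4-hydroxy-3-methoxyphenyl to 3,4-dimethoxyphenyl and the second 4-hydroxyphenyl to 4-methoxyphenyl.

Because the same change between compound 1 and compound 2 gave a 1.3-fold lower number from compound 1 to compound 2 (0.12 log units; within the scatter), a step of similar size is expected here, a step that the limit leaves unreadable from compound 3 to compound 4. As compound 3 sits at a limit, it is expected that compound 4 will most likely also be reported only as a limit, with an estimated value of 500000 nM, between 150000 nM and 2000000 nM.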

Compound 4, half-maximal cytotoxic concentration: > 400000 nM
Compound 4: only a limit was reported; the forecaster's own chance of this, stated with the estimate: 75%; the middle value does not contradict the limit.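

Compound 3 and compound 4 are both reported in this assay only as limits, not as numbers, so the size of the step between them cannot be read: the limit of > 400000 nM in this assay, at which 2 of the 4 values shown sit.

The compounds shown leave open how much of compound 3 or compound 4 is actually tolerated, and so whether methyl in place of hydrogen on that oxygen changes the number on this core at all.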